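A few compounds are considered here, and "the series" means these few. Any claim that something is new, unique, unknown or untested is made for them only; others in the source may bear on it.

Measured so far in a functional assay on MDA-MB-231 cells (Homo sapiens) for antiproliferative activity, read by sulforhodamine B assay, with a stated time of 48 h; a higher number here means a weaker inhibitor, a lower number a stronger inhibitor:
- Compound 1 `COc1ccc(C(=O)/C=C\Nc2ccc(-c3nc4cc(OC)c(OC)c(OC)c4s3)cc2C)cc1O`: 12400 nM
- Compound 2 `COc1ccc(C(=O)/C=C\Nc2ccc(-c3nc4cc(OC)c(OC)c(OC)c4s3)cc2C)cc1[N+](=O)[O-]`: 12400 nM
- Compound 3 `COc1cc(OC)c2sc(-c3ccc(N/C=C\C(=O)c4cc(OC)c(OC)c(OC)c4)c(C)c3)nc2c1`: 13800 nM

All three values, that of compound 3 included, lie within the usual scatter of one another. Compound 4 `COc1cc(C(=O)/C=C\Nc2ccc(-c3nc4cc(OC)c(OC)c(OC)c4s3)cc2C)cc(OC)c1OC` differs from compound 3 by one change: methoxy in place of hydrogen on an aromatic carbon, ortho to two methoxy groups (methoxy in place of hydrogen on an aromatic carbon). For the measured compounds named here, no measured step makes this exact change. Going by the values given here, the only step available swaps hydroxy for nitro on another ring, and it shows no change at the digits printed from compound 1 to compound 2 (within the scatter). Compound 1 and compound 2 already carry the core of compound 4, and compound 2 still gives 12400 nM. No shift beyond the scatter is therefore expected in this assay. The expected step is a 1.2-fold lower number from compound 3 to compound 4 (0.06 log units; within the scatter). For compound 4 the estimated value is 12000 nM, with an expected range of 5500 nM to 27000 nM.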

Compound 4, half-maximal inhibitory concentration: 12900 nM
For compound 4 the middle estimate is 1.1-fold (0.03 log units) below the measured one; low and high end bracket the measured number.
By their numbers in this assay, from the lowest: compounds 1, 2, 4 and 3 (each within the scatter of the next).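

In this assay methoxy in place of hydrogen on the aromatic carbon ortho to two methoxy groups gives a 1.1-fold lower number from compound 3 to compound 4 (0.03 log units; within the scatter) and so no real shift at this position. Putting 3,4,5-trimethoxyphenyl on the carbonyl carbon in place of the other two aryl groups gives a 1.0-fold higher number from compound 2 to compound 4 (0.02 log units; within the scatter) and a 1.0-fold higher number from compound 1 to compound 4 (0.02 log units; within the scatter) and so no real shift either. Nothing available explains why these numbers stay so close. Still open, on these data alone, is whether a different group at this position, such as an amine or a carboxylic acid, would move the number beyond the scatter.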